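Phenyl to Dimethoxyphenyl at the Carbon Double-Bonded to Nitrogen

The compounds below may be only part of what the source reports. "The series", "measured", "known", "first", "only" and "open" are said of these compounds alone.

Compound 1 `COc1cc(-c2nnc(SCc3ccc(F)cc3)n2/N=C/c2ccccc2)cc(OC)c1OC` carries a plain phenyl on the carbon with a double bond to nitrogen. In a functional assay on HT-29 cells (Homo sapiens) for cytotoxicity, read by MTT assay, with a stated time of 48 h (a higher number here means a weaker inhibitor, a lower number a stronger inhibitor), compound 1 gives > 200000 nM, which is a limit of the assay rather than a measured number. Compound 2 `COc1cc(-c2nnc(SCc3ccccc3Cl)n2/N=C/c2ccccc2)cc(OC)c1OC` differs from compound 1 only in its sulfur-bound arm, a 2-chlorophenyl in place of 4-fluorophenyl on a saturated chain carbon bound to a sulfur. In this assay compound 2 gives > 200000 nM, also a limit. The step that the two limits leave unreadable from compound 1 to compound 2 therefore cannot be sized, because of the limit of > 200000 nM in this assay, at which 2 of the 2 values shown sit. Compound 3 `COc1ccc(/C=N/n2c(SCc3ccc(F)cc3)nnc2-c2cc(OC)c(OC)c(OC)c2)c(OC)c1` has not yet been measured; it differs from compound 1 by 2,4-dimethoxyphenyl in place of phenyl on a carbon with a double bond to nitrogen. Among the compounds with values here, the one measured step does not touch this part of the molecule, and both measured values stop at the limit, so nothing here gives the size or direction of the coming step. The expectation for compound 3 is simply that it too ends at the limit. The expected step that the limit leaves unreadable from compound 1 to compound 3 is therefore none beyond the scatter. Compound 3 is estimated at 250000 nM, in a range from 100000 nM to 600000 nM.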

Compound 3, half-maximal inhibitory concentration: 126000 nM
Estimate against measurement, compound 3: 2.0-fold (0.30 log units) above; measured number inside the range.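

Compound 3 is the first compound shown to give a real number rather than a limit in this assay, and this comes with 2,4-dimethoxyphenyl in place of phenyl on a carbon with a double bond to nitrogen. The change gives an at least 1.5-fold lower number from compound 1 to compound 3 (0.20 log units; that floor lies within the scatter), so the position can shift the reading, but the step as printed does not show a change beyond the scatter. The step has a firm reading at only one end, since compound 1 is itself a limit and not a number: the limit of > 200000 nM in this assay, at which 2 of the 3 values shown sit.

The compounds shown leave open whether a single methoxy group on this phenyl, or a different group such as an amine or a carboxylic acid at the same place, would move the number further from the limit. Going by these compounds, it also remains open whether 2,4-dimethoxyphenyl would bring a measurable number when paired with the 2-chlorophenyl arm of compound 2 rather than the 4-fluorophenyl arm of compound 3.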